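The source may report more compounds than this note shows. Statements on the series, on what has been measured and on what is new or still open speak of the compounds shown alone.

Compound 1, `COc1cc(-c2ccnc3cc(-c4c[nH]c5ccccc45)nn23)cc(OC)c1OC`, stands at the lowest number of the values shown in a functional assay on A549 cells (Homo sapiens) for inhibition, read by CCK-8 assay, with a stated time of 48 h; a higher number here means a weaker inhibitor, a lower number a stronger inhibitor: compound 1 gives 29 nM. Compound 2, `COc1cc(-c2ccnc3cc(-c4ccc(Cl)cc4)nn23)cc(OC)c1OC`, gives 3070 nM in this assay. Compound 3, `CCOC(=O)c1ccc(-c2cc3nccc(-c4cc(OC)c(OC)c(OC)c4)n3n2)cc1`, reaches only a limit of this assay, reported as > 10000 nM.

Two measured steps frame the present question. The step of a 110-fold higher number from compound 1 to compound 2 (2.02 log units; beyond the scatter) shows what the exchange of the indole for a substituted phenyl cost, and the step of an at least 3.2-fold higher number from compound 2 to compound 3 (0.51 log units; beyond the scatter) shows that a different group on that phenyl lost still more, ending at the limit (the limit of > 10000 nM in this assay, at which 1 of the 3 values shown sits).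

Compound 4, `COc1cc(-c2ccnc3cc(-c4ccc(C(C)(C)C)cc4)nn23)cc(OC)c1OC`, differs from compound 1 in one place: 4-(tert-butyl)phenyl in place of 1H-indol-3-yl on an aromatic carbon. The first of the measured steps bears directly on this change, since compound 4 likewise trades the 1H-indol-3-yl for a phenyl bearing one group, and the second step gives no sign that such phenyl variants recover potency. A large rise in the number, of the order seen between compound 1 and compound 2, is therefore expected. Compound 4 is estimated to give 3000 nM in this assay, within a range from 800 nM to 10000 nM. The expected step from compound 1 to compound 4 is accordingly a 100-fold higher number from compound 1 to compound 4 (2.01 log units; beyond the scatter).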

Compound 4, half-maximal inhibitory concentration: > 10000 nM
Compound 4 was reported as a limit (the forecaster's own chance of this, stated with the estimate: 25%); middle value at least 3.3-fold (0.52 log units) from the limit.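

Replacing the 1H-indol-3-yl with 4-(tert-butyl)phenyl gives an at least 340-fold higher number from compound 1 to compound 4 (2.53 log units; beyond the scatter), so a further phenyl variant, with a bulkier-named group than chloro but no hydrogen-bond donor, also fails to keep the activity of compound 1. Changing only the group on the phenyl gives an at least 3.2-fold higher number from compound 2 to compound 4 (0.51 log units; beyond the scatter), so compound 2 remains the only phenyl compound shown that returns a number, while the step between compound 3 and compound 4 cannot be read, as both values are limits. Compound 4 is reported only as a limit in this assay, which a second compound now shares: the limit of > 10000 nM in this assay, at which 2 of the 4 values shown sit.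

The compounds shown leave open whether the activity of compound 1 depends on the hydrogen-bond donor of the 1H-indol-3-yl or on its second ring. An indole with a methyl on its ring nitrogen, a naphthyl group, or a phenyl bearing an amine would help separate these.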